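The source may report more compounds than this note shows. Statements on the series, on what has been measured and on what is new or still open speak of the compounds shown alone.

Measured so far in an ADME assay on NCM460 cells (Homo sapiens) for cytotoxicity, read by CCK-8 assay, with a stated time of 48 h; on this read-out lower numbers stand for stronger inhibition and higher numbers for weaker inhibition:
- compound 1 `COc1ccc(/C=C\c2cc(OC)c(OC)c(OC)c2)cc1OCc1ccc(CNC(C)(C)C(=O)O)cc1`: > 50000 nM, a limit of the assay, not a number
- compound 2 `COc1ccc(/C=C\c2cc(OC)c(OC)c(OC)c2)cc1OCc1ccc(CNCCO)cc1`: 39000 nM

Compound 1 stands at the limit only; it sits at the limit of > 50000 nM in this assay, at which 1 of the 2 values shown sits, so its true value is not pinned down. Within the data shown here, the one measured step, an at least 1.2-fold lower number from compound 1 to compound 2 (0.10 log units; that floor lies within the scatter), is a floor that lies within the scatter, so it shows no change beyond the scatter.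

Compound 3 `COc1ccc(/C=C\c2cc(OC)c(OC)c(OC)c2)cc1OCc1ccc(CO)cc1` differs from compound 1 by hydroxy in place of (1-carboxy-1-methylethyl)amino on a saturated chain carbon bound to an aromatic carbon. Among the measured compounds shown here, no measured step matches this change exactly; the only related one is the step from compound 1 to compound 2, which also removed the 1-carboxy-1-methylethyl group and stayed within the scatter. On that basis the expected step of an at least 1.1-fold lower number from compound 1 to compound 3 (0.04 log units; that floor lies within the scatter) is small, with no direction beyond the scatter, and there is a fair chance that compound 3 again returns only a limit. The estimate for compound 3 in this assay is 45000 nM, with a range from 18000 nM to 110000 nM.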

Compound 3, half-maximal inhibitory concentration: > 50000 nM
Compound 3: only a limit was reported; the forecaster's own chance of this, stated with the estimate: 50%; at least 1.1-fold (0.04 log units) between middle value and limit.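

Working notes on the chain carbon bound to an aromatic carbon, in this assay. Hydroxy in place of (2-hydroxyethyl)amino at this place gives an at least 1.2-fold higher number from compound 2 to compound 3 (0.10 log units; that floor lies within the scatter), so this change, like the earlier one on the amine nitrogen, shows no shift beyond the scatter. With the hydroxy, the nitrogen-bearing side chain is gone altogether, and compound 3 gives > 50000 nM, a limit of the assay and not a number, so this place now has a member with neither the amine nitrogen nor the carboxy group and still no reading inside the assay's range. The step between compound 1 and compound 3 cannot be read, and the series gains no size for that change, because both compounds stand at the same limit: the limit of > 50000 nM in this assay, at which 2 of the 3 values shown sit.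

Going by these compounds, how far compound 1 and compound 3 lie past that limit stays open, so any real gap between them remains unknown. Also open, on these data alone, is whether a simple primary amine, a carboxylic acid without the amine nitrogen, or a longer chain on this carbon would give a number clearly different from the values seen here.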